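Compound 3 to compound 4: cyclooctylamino on the shared core

The source may report more compounds than this note shows. Statements on the series, on what has been measured and on what is new or still open speak of the compounds shown alone.

Compound 1 `CCCCCCCNc1ncnc2c1ncn2[C@@H]1O[C@H](COS(N)(=O)=O)[C@@H](O)[C@H]1O`, compound 2 `CC(C)(C)CC(C)(C)Nc1ncnc2c1ncn2[C@@H]1O[C@H](COS(N)(=O)=O)[C@@H](O)[C@H]1O` and compound 3 `CN(Cc1ccco1)c1ncnc2c1ncn2[C@@H]1O[C@H](COS(N)(=O)=O)[C@@H](O)[C@H]1O` differ only in the group on an aromatic carbon of the shared core. In a functional assay on K562 cells (Homo sapiens) for antiproliferative activity, read by CellTiter-Glo, with a stated time of 72 h (a higher number here means that more compound is needed for the effect, a lower number that less compound is needed), compound 1 gives 132 nM as a measured number. Compound 2 gives > 1000 nM, which is a limit. Compound 3 gives > 1000 nM, also a limit. Compound 3 therefore has no number of its own and shares its position with compound 2: the limit of > 1000 nM in this assay, at which 2 of the 3 values shown sit.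

Compound 4 `NS(=O)(=O)OC[C@H]1O[C@@H](n2cnc3c(NC4CCCCCCC4)ncnc32)[C@H](O)[C@@H]1O` brings this change: cyclooctylamino in place of ((furan-2-yl)methyl)(methyl)amino on an aromatic carbon. Among the measured compounds shown here, two measured steps bear on it, an at least 7.5-fold higher number from compound 1 to compound 3 (0.87 log units; beyond the scatter) and an at least 7.5-fold higher number from compound 1 to compound 2 (0.87 log units; beyond the scatter). Compound 1 keeps a measured number with heptylamino, but compound 2 goes against any simple reading of all-carbon groups on that nitrogen. A modest move to a lower number is therefore expected, and a second limit remains possible. The expected step is an at least 2.8-fold lower number from compound 3 to compound 4 (0.45 log units; beyond the scatter) in this assay. Compound 4 is estimated at 350 nM, within an expected range of 100 nM to 1000 nM.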

Compound 4, half-maximal effective concentration: 380 nM
For compound 4 the middle estimate is 1.1-fold (0.04 log units) below the measured one, and the stated range covers the measured number.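

In this assay, among the compounds shown here, cyclooctylamino is the first ring-bearing group at this position to give a measured number, and replacing the ((furan-2-yl)methyl)(methyl)amino group gives an at least 2.6-fold lower number from compound 3 to compound 4 (0.42 log units; beyond the scatter). Among the all-carbon groups on this nitrogen, a measured number is therefore not confined to the straight heptyl chain: cyclooctyl in place of 1,1,3,3-tetramethylbutyl gives an at least 2.6-fold lower number from compound 2 to compound 4 (0.42 log units; beyond the scatter). Heptyl nevertheless keeps the lower number, with cyclooctyl in its place giving a 2.9-fold higher number from compound 1 to compound 4 (0.46 log units; beyond the scatter).

From the compounds shown here alone, the true sizes of the steps from compound 2 and compound 3 remain open, since each starts from a limit and not from a number: the limit of > 1000 nM in this assay, at which 2 of the 4 values shown sit. Also open is how a smaller ring such as cyclohexyl, or a longer chain such as octyl, on the same nitrogen would compare with cyclooctyl and heptyl.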